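This account rests on a few compounds, and the source may have more. Where it says the series, first, only, none or still open, it means among the compounds named here.

Compound 2 (`CC(C)[C@H](NC(=O)COc1cccc2ccccc12)C(=O)N[C@@H](CC(=O)O)C(=O)COc1ccc(F)cc1`) carries a 4-fluorophenyl on an oxygen on a saturated carbon. In a functional assay with Homo sapiens as the target (a higher number here means a weaker inhibitor, a lower number a stronger inhibitor), compound 2 gives 14300 nM and stands level with compound 1 (`CC(C)[C@H](NC(=O)COc1cccc2ccccc12)C(=O)N[C@@H](CC(=O)O)C(=O)COC(=O)c1c(Cl)cccc1Cl`), which gives 11500 nM as its value. Between them lies the only measured step, a 1.2-fold higher number from compound 1 to compound 2 (0.09 log units; within the scatter) in this assay for the exchange of (2,6-dichlorophenyl)carbonyl for 4-fluorophenyl, and that step stays within the scatter.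

Compound 3 (`CC(C)[C@H](NC(=O)COc1cccc2ccccc12)C(=O)N[C@@H](CC(=O)O)C(=O)COc1ccc(F)cc1F`) differs from compound 2 in one place: fluoro in place of hydrogen on an aromatic carbon describes fluoro in place of hydrogen on an aromatic carbon, so that 4-fluorophenyl becomes 2,4-difluorophenyl. For the measured compounds named here, no measured pair tests this edit directly. Going by the values given here, the one available comparison, compound 1 against compound 2, swaps a whole group and still shows no shift beyond the scatter, though two compounds are thin evidence. No clear direction is therefore expected, and the expected change is a 1.2-fold lower number from compound 2 to compound 3 (0.08 log units; within the scatter) in this assay and so within the scatter. Compound 3 is estimated at 12000 nM with an expected range from 5000 nM to 30000 nM for now.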

Compound 3, half-maximal inhibitory concentration: 17600 nM
The estimate for compound 3 lay 1.5-fold (0.17 log units) below the measured number; measured number inside the range.
By their numbers in this assay, from the lowest: compounds 1, 2 and 3 (each within the scatter of the next).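

In this assay, fluoro in place of hydrogen on an aromatic carbon, ortho to a large group and meta to a fluoro group, turns 4-fluorophenyl into 2,4-difluorophenyl and gives no readable shift (a 1.2-fold higher number from compound 2 to compound 3 (0.09 log units; within the scatter)), so this position accepts the added fluoro without a change that can be separated from the scatter. The wider exchange of (2,6-dichlorophenyl)carbonyl for 2,4-difluorophenyl on the same oxygen also stays within the scatter (a 1.5-fold higher number from compound 1 to compound 3 (0.18 log units; within the scatter)), which means that compounds 1, 2 and 3 now form a level set in this assay despite the different groups on that oxygen. No supporting measurement is available to explain this flat response.

On these data alone, it remains open whether an amine, a nitrile or a methoxy group at this ring position, or a longer chain on the oxygen, would move the number beyond the scatter. As far as these compounds go, all three compounds share the rest of the core, so the response of this assay to changes elsewhere in that core also remains unknown.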